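The compounds below may be only part of what the source reports. "The series", "measured", "known", "first", "only" and "open" are said of these compounds alone.

Among the compounds with values here, in an ADME assay on HEL cells (Homo sapiens) for cytotoxicity, with a stated time of 3 days (on this read-out lower numbers stand for higher toxicity in this test and higher numbers for lower toxicity in this test), compound 1 `C=Cc1ccc(-c2cc(C)c3ncc(CSCCc4ccccc4)n3c2)cc1` gives 14 ug/mL, the lowest of the three numbers measured so far. Compound 2 `Cc1cc(N2CCN(C)CC2)cn2c(CSCCc3ccccc3)cnc12` gives 32 ug/mL, and compound 3 `Cc1cc(-n2ccc3ccccc32)cn2c(CSCCc3ccccc3)cnc12` gives 18 ug/mL. The change leading to compound 4 `Cc1cc(-n2ccc3cccnc32)cn2c(CSCCc3ccccc3)cnc12` is a group of 9 heavy atoms (7 carbon, 2 nitrogen; one five-membered aromatic ring with 1 hetero atom, one six-membered aromatic ring with 1 hetero atom) in place of a group of 8 heavy atoms (8 carbon; one six-membered aromatic ring of carbon only), on an aromatic carbon. Within the data shown here, the nearest measured step is the one to compound 3, which carries 1H-indol-1-yl on the same aromatic carbon: a 1.3-fold higher number from compound 1 to compound 3 (0.11 log units; within the scatter). Among the measured compounds shown here, the step of a 2.3-fold higher number from compound 1 to compound 2 (0.36 log units; beyond the scatter) is larger, but that group has less in common with the one entering compound 4. Because the step of a 1.3-fold higher number from compound 1 to compound 3 (0.11 log units; within the scatter) stayed within the scatter, a similarly small move is expected for compound 4: a 1.3-fold higher number from compound 1 to compound 4 (0.11 log units; within the scatter). Compound 4 is therefore estimated at 18 ug/mL, with a range from 9 ug/mL to 36 ug/mL.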

Compound 4, half-maximal cytotoxic concentration: 16 ug/mL
For compound 4 the middle estimate is 1.1-fold (0.05 log units) above the measured one; low and high end bracket the measured number.
By their numbers in this assay, from the lowest: compounds 1, 4, 3 and 2 (each within the scatter of the next, the first and the last beyond it).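

Replacing one carbon of 1H-indol-1-yl with nitrogen gives a step within the scatter in this assay (a 1.1-fold lower number from compound 3 to compound 4 (0.05 log units; within the scatter)). Compound 4 also stays within the scatter of the compounds carrying 4-vinylphenyl (a 1.1-fold higher number from compound 1 to compound 4 (0.06 log units; within the scatter)) and 4-methylpiperazin-1-yl (a 2.0-fold lower number from compound 2 to compound 4 (0.30 log units; within the scatter)), so this added ring nitrogen gives no readable separation at this aromatic carbon. No supporting measurement bears on this result.

Still open is whether a carboxylic acid or a primary amine on this same aromatic carbon would give a number beyond the scatter of these compounds.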